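The compounds below may be only part of what the source reports. "The series", "measured", "known", "first", "only" and "open" are said of these compounds alone.

Measured so far:
compound 1 `COc1cc(/C=C2\CCC/C(=C\c3ccc([N+](=O)[O-])cc3)C2=O)ccc1O` — 2800 nM in a functional assay on HSC-2 cells (Homo sapiens) for cytotoxicity; a lower number here means that less compound is tolerated, a higher number that more compound is tolerated
compound 2 `COc1ccc(/C=C2\CCC/C(=C\c3ccc([N+](=O)[O-])cc3)C2=O)cc1OC` — 2300 nM in this assay

Among the compounds with values here, compound 2 gives the lowest of the two numbers; its nearest neighbour is compound 1, and the only step on record, a 1.2-fold lower number from compound 1 to compound 2 (0.09 log units; within the scatter), lies within the scatter. Compound 3 `COc1cc(/C=C2\CCC/C(=C\c3ccc([N+](=O)[O-])cc3)C2=O)cc(OC)c1OC` is the next member. It differs from compound 2 by methoxy in place of hydrogen on an aromatic carbon. Within the data shown here, the one comparable step, a 1.2-fold lower number from compound 1 to compound 2 (0.09 log units; within the scatter), adds a methyl on an oxygen without moving the number beyond the scatter, so no shift beyond the scatter is expected here either: the step of no change at the digits printed from compound 2 to compound 3 (within the scatter) is the estimate. For compound 3 the expected value in this assay is 2300 nM, with a range of 1000 nM to 5500 nM.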

Compound 3, half-maximal cytotoxic concentration: 760 nM
Estimate against measurement, compound 3: 3.0-fold (0.48 log units) above; measured number outside the range, below it.
By their numbers in this assay, from the lowest: compound 3; then compounds 2 and 1 (each within the scatter of the next).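

In this assay, within the data shown here, the methoxy on the aromatic carbon, ortho to a methoxy group, gives the first step beyond the scatter: a 3.0-fold lower number from compound 2 to compound 3 (0.48 log units; beyond the scatter). A change on this ring carbon can therefore move the number, whereas the methyl on an oxygen did not do so in a 1.2-fold lower number from compound 1 to compound 2 (0.09 log units; within the scatter). Nothing available on the compounds accounts for the shift. On these data alone, whether it is specific to methoxy remains open. A fluorine, a hydroxyl, an amine or a longer alkoxy chain on this carbon would test that.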